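Methoxy and amine changes on the shared core

This account rests on a few compounds, and the source may have more. Where it says the series, first, only, none or still open, it means among the compounds named here.

Compound 1 `CCC(=O)Nc1cccc(Oc2nc(Nc3ccc(N4CCC(OC)CC4)cc3OC)ncc2Cl)c1` gives 5.08% in an assay on isolated protein for inhibition of NUAK family SNF1-like kinase 1 (Homo sapiens), read by ADP-Glo, with a stated time of 60 min, tested at 10 uM, in the presence of a further agent that is not named here (on this read-out higher numbers stand for more inhibition at the one concentration tested (going by the name of the read-out) and lower numbers for less inhibition), the lowest of the three numbers here. Compound 2 `CCC(=O)Nc1cccc(Oc2nc(Nc3ccc(N4CCC(OC)CC4)cc3)ncc2Cl)c1` gives 86.5% and compound 3 `CCC(=O)Nc1cccc(Oc2ccnc(Nc3ccc(N4CCN(C)CC4)cc3)n2)c1` gives 85.6%; the nearest to compound 1 is compound 3. Among the compounds with values here, the one single-point step, a number 81.4 percentage points higher from compound 1 to compound 2 (beyond the scatter), concerns the methoxy on the aromatic ring. Compound 4 `CCCN(CCC)c1ccc(Nc2ncc(Cl)c(Oc3cccc(NC(=O)CC)c3)n2)c(OC)c1` keeps that methoxy and differs from compound 1 elsewhere: dipropylamino in place of 4-methoxypiperidin-1-yl on an aromatic carbon. Within the data shown here, no measured step changes the 4-methoxypiperidin-1-yl group, so nothing here bears directly on this change. Compound 4 is therefore expected to stay near compound 1 because of 5.08%, with a step of a number 4.9 percentage points higher from compound 1 to compound 4 (within the scatter) not beyond the scatter. The estimate for compound 4 is 10%, in the range 0% to 35%.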

Compound 4, a percentage reported as inhibition, at one concentration (the size of the read-out at that concentration, not a potency): "not active" (no number reported)
For compound 4 the study gives words and no number, so the estimate cannot be set against anything.
By their numbers in this assay, from the lowest: compound 1; then compounds 3 and 2 (each within the scatter of the next).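

Within the data shown here, compound 4 is reported in words without a number, so no step from compound 1 to compound 4 can be read. The compounds shown leave open what dipropylamino in place of 4-methoxypiperidin-1-yl does to inhibition. Nothing here accounts for the result.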